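Propyl to 4-fluorobenzyl on a leukotriene C4 synthase inhibitor scaffold

The compounds below may be only part of what the source reports. "The series", "measured", "known", "first", "only" and "open" are said of these compounds alone.

Going by the values given here, compound 2 `CCCN(c1cccc(C(F)(F)F)c1)c1cnc(C(=O)[C@H]2C[C@@H]2C(=O)O)c(OC)c1` is the only compound of this series with a number in an assay on isolated protein for inhibition of leukotriene C4 synthase (Homo sapiens), read by LC-MS, with stated times of 45 min and 20 min; a higher number here means a weaker inhibitor, a lower number a stronger inhibitor: compound 2 gives 58.4 nM. Compound 1 `COc1cc(N(CC(C)(C)O)c2cccc(C(F)(F)F)c2)cnc1C(=O)[C@H]1C[C@@H]1C(=O)O`, which shares the core and the carboxylic acid, has in this assay only the entry "not determined" (no result reported), so compound 2 stands alone as the reference point. Compound 3 `COc1cc(N(Cc2ccc(F)cc2)c2cccc(C(F)(F)F)c2)cnc1C(=O)[C@H]1C[C@@H]1C(=O)O` is not yet measured. It differs from compound 2 in one place: 4-fluorophenyl in place of ethyl on a saturated chain carbon bound to a nitrogen on an aromatic ring. Among the compounds with values here, nothing among the measured compounds shows how this change plays out, so the expected step from compound 2 to compound 3 in this assay is estimated as a 1.3-fold lower number from compound 2 to compound 3 (0.11 log units; within the scatter), a shift that is not expected to go clearly beyond the usual scatter in either direction. On that basis, compound 3 is expected to give an estimated 45 nM in this assay, with a likely range from 12 nM to 150 nM.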

Compound 3, half-maximal inhibitory concentration: 157 nM
Estimate against measurement, compound 3: 3.5-fold (0.54 log units) below; the measured number lies above the stated range.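

The position on the saturated chain carbon bound to a nitrogen on an aromatic ring proves sensitive to what it carries: in this assay, the change from propyl to 4-fluorobenzyl gives a 2.7-fold higher number from compound 2 to compound 3 (0.43 log units; beyond the scatter). The step is modest, and even with an aromatic ring in this place compound 3 keeps a measurable inhibition of 157 nM, so this position tolerates the larger group at a limited cost. Nothing at hand accounts for the step.

The compounds shown leave open whether the step goes with the aromatic ring itself or with its fluorine, and how a plain benzyl group or a longer chain such as butyl would read here. Compound 1, with its hydroxyl-bearing chain, offers no comparison, as its entry is "not determined" (no result reported).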